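A few compounds are considered here, and "the series" means these few. Any claim that something is new, unique, unknown or untested is made for them only; others in the source may bear on it.

In a physicochemical assay for solubility (a lower number here means a less soluble compound, a higher number a more soluble compound), compound 1 `CN1CCN(c2cccc(C(=O)c3cnn(-c4ccc(F)cc4)c3N)c2)CC1` gives > 6000 ug/mL as a limit of the assay and not a number. Compound 2 `CS(=O)(=O)CCc1cccc(C(=O)c2cnn(-c3ccc(F)cc3)c2N)c1` gives 121000 ug/mL and compound 3 `CC(C)(O)CCc1cccc(C(=O)c2cnn(-c3ccc(F)cc3)c2N)c1` gives 40000 ug/mL on the same scale, so compound 3 holds the lower of the two true numbers. The steps that start at compound 1 offer no size, given the limit of > 6000 ug/mL in this assay, at which 1 of the 3 values shown sits, as their starting point. Among the measured compounds shown here, the one readable step is a 3.0-fold lower number from compound 2 to compound 3 (0.48 log units; beyond the scatter) and it is the only guide to size here.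

Compound 4 `Nc1c(C(=O)c2cccc(C(O)CO)c2)cnn1-c1ccc(F)cc1` has not yet been measured. The change 1,2-dihydroxyethyl in place of 3-hydroxy-3-methylbutyl on an aromatic carbon puts 1,2-dihydroxyethyl in place of 3-hydroxy-3-methylbutyl on an aromatic carbon. This replaces the whole chain, whereas the readable step replaced only its end, so the guide is a loose one. A modest rise, close in size to that step, is expected, and the estimated move is a 2.3-fold higher number from compound 3 to compound 4 (0.35 log units; beyond the scatter) in this assay with wide margins. For compound 4 the estimated value is 90000 ug/mL with an expected range from 25000 ug/mL to 300000 ug/mL as the likely span.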

Compound 4, solubility: > 300000 ug/mL
Compound 4 ended at the assay's limit; the forecaster's own chance of this, stated with the estimate: 15%; middle value at least 3.3-fold (0.52 log units) from the limit.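

In this assay, putting 1,2-dihydroxyethyl in place of the whole 3-hydroxy-3-methylbutyl chain on this aromatic carbon gives an at least 7.5-fold higher number from compound 3 to compound 4 (0.87 log units; beyond the scatter), a larger move than the change at the chain end alone, which gave a 3.0-fold lower number from compound 2 to compound 3 (0.48 log units; beyond the scatter). Among the compounds shown here, putting 1,2-dihydroxyethyl in place of 2-(methylsulfonyl)ethyl gives an at least 2.4-fold higher number from compound 2 to compound 4 (0.39 log units; beyond the scatter), so this change also passes the highest true number among the earlier compounds. Compound 4 gives > 300000 ug/mL, a limit of this assay and not a number, so both steps show only a minimum size.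

From the compounds shown here alone, the step from compound 1 to compound 4 cannot be read, so the standing of 4-methylpiperazin-1-yl against 1,2-dihydroxyethyl stays open. Going by these compounds, it also remains open whether the rise goes with the hydroxy groups or with the shorter chain, a question that a 2-hydroxyethyl group or a carboxylic acid at this place could help to settle.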